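Swapping the thiosemicarbazone tail for a benzylthio group

The compounds below may be only part of what the source reports. "The series", "measured", "known", "first", "only" and "open" are said of these compounds alone.

Of the compounds shown here, three that share one core have been tested in a functional assay on MCF7 cells (Homo sapiens) for antiproliferative activity, read by MTT assay, with a stated time of 72 h; a lower number here means a stronger inhibitor, a higher number a weaker inhibitor. Compound 1 `Cc1ccc(NC2=C/C(=N/NC(N)=S)C(=O)N=C2Nc2ccc(C)cc2)cc1` is the strongest of them: compound 1 gives 3060 nM, while compound 2 `COc1ccccc1NC1=C/C(=N/NC(N)=S)C(=O)N=C1Nc1ccccc1OC` gives 10200 nM and compound 3 `Cc1ccccc1NC1=C/C(=N/N=C(\N)SCc2ccccc2)C(=O)N=C1Nc1ccccc1C` gives 16300 nM, both gaps lying beyond the usual scatter.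

Compound 4 `Cc1ccc(NC2=C/C(=N/N=C(\N)SCc3ccccc3)C(=O)N=C2Nc2ccc(C)cc2)cc1` differs from compound 1 in one place: a group of 11 heavy atoms (8 carbon, 2 nitrogen, 1 sulfur; one six-membered aromatic ring of carbon only) in place of a group of 4 heavy atoms (1 carbon, 2 nitrogen, 1 sulfur; no ring), on a double-bonded nitrogen. Going by the values given here, no measured pair shows this exact change, so its effect can only be estimated. Because compound 3 gives 16300 nM, a weaker result than compound 1 in this assay, a loss of potency seems more likely than a gain.

For compound 4 the expected value is 8000 nM, probably between 2500 nM and 25000 nM. That amounts to an expected step of a 2.6-fold higher number from compound 1 to compound 4 (0.42 log units; beyond the scatter), a moderate weakening.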

Compound 4, half-maximal inhibitory concentration: 13400 nM
For compound 4 the middle estimate is 1.7-fold (0.22 log units) below the measured one, within the range that was stated.
By their numbers in this assay, from the lowest: compound 1; then compounds 2, 4 and 3 (each within the scatter of the next).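

Going by these compounds alone, compounds 1 and 4 differ in one place only, so this pair isolates the change that the earlier compounds could not. In this assay, putting the larger group with its six-membered aromatic ring on the double-bonded nitrogen gives a 4.4-fold higher number from compound 1 to compound 4 (0.64 log units; beyond the scatter), so here the swap costs potency without abolishing activity. No measurement shown here gives a reason for this loss.

From the compounds shown here alone, it remains open whether a single methyl group on the sulfur would cost as much as the benzyl group. The compounds shown also leave open whether the same swap has a similar effect on compound 2.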